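This account rests on a few compounds, and the source may have more. Where it says the series, first, only, none or still open, it means among the compounds named here.

Compound 1 `O=C(/C=C1\CCc2ccc(F)cc21)NCC1CC1`: in a functional assay on the whole organism with Rattus norvegicus as the target, at a dose of 20 mg/kg by the oral route (on this read-out lower numbers stand for less inhibition and higher numbers for more inhibition at the one dose given (going by the name of the read-out)), compound 1 gives 21%.
Compound 2 `O=C(/C=C1\CCc2ccc(F)cc21)NCCO`: compound 2 gives 78%.
Compound 3 `O=C(/C=C1\CCc2ccc(Br)cc21)NC1CC1`: compound 3 gives 4%.

Of the three measured compounds, compound 3 stands lowest in this assay: its nearest neighbour is compound 1, a number above it by more than the usual scatter, and compound 2 stands furthest from it, higher still.

Compound 4 `O=C(/C=C1\CCc2ccc(F)cc21)NC1CC1` has not yet been measured. It differs from compound 3 in one place: fluoro in place of bromo on an aromatic carbon. For the measured compounds named here, the only measured step in this set, a number 57 percentage points higher from compound 1 to compound 2 (beyond the scatter), concerns a change on the saturated chain carbon bound to the amide-type nitrogen, not a change on the aromatic ring, so it does not bear on the bromo-to-fluoro swap. Compounds 1 and 2 both carry fluoro and were measured only with other amide substituents, so their values speak to the amide side rather than to the halogen. Going by the values given here, no measured pair shows what swapping bromo for fluoro alone does here.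

Among the compounds with values here, with no step to lean on, the expectation for a number 8 percentage points higher from compound 3 to compound 4 (within the scatter) is a change not clearly beyond the scatter, with a slight lean upward given that compound 1, which also carries fluoro, gives 21%. Compound 4 is therefore estimated at 12%, with a range from 0% to 35%.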

Compound 4, a percentage reported as inhibition, in the whole organism at one dose (the size of the read-out at that dose, not a potency): 7%
For compound 4 the middle estimate is 5 percentage points above the measured one; low and high end bracket the measured number.
By their numbers in this assay, from the lowest: compounds 3 and 4 (each within the scatter of the next); then compound 1; then compound 2.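

In this assay the change of bromo to fluoro on this aromatic carbon gives a number 3 percentage points higher from compound 3 to compound 4 (within the scatter) with cyclopropyl on the amide-type nitrogen, so at this position, with this amide group, the two halogens cannot be told apart. With fluoro held fixed, the amide side carries the clear differences: cyclopropyl in place of 2-hydroxyethyl gives a number 71 percentage points lower from compound 2 to compound 4 (beyond the scatter) and cyclopropyl in place of cyclopropylmethyl gives a number 14 percentage points lower from compound 1 to compound 4 (beyond the scatter) in the same whole-animal test, so among these compounds the group on the nitrogen matters far more than the halogen. No measurement among the data shown explains any of these differences.

From the compounds shown here alone, the halogen result comes from a single pair at the low end of the scale, so it remains open whether bromo and fluoro would also match with 2-hydroxyethyl on the nitrogen, where the number is much higher. Also open, going by these compounds, is what a chloro or a methoxy group would give on this aromatic carbon, and how a longer chain such as 3-hydroxypropyl, or a 2-aminoethyl group, would compare with 2-hydroxyethyl on the amide-type nitrogen.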